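Swapping the nitrogen side chain of compound 1 for a bulkier benzyl

This account rests on a few compounds, and the source may have more. Where it says the series, first, only, none or still open, it means among the compounds named here.

Measured compounds:
- compound 1 `COc1cc2c(=O)c(C(=O)c3ccc(C)cc3)cn(CCCc3ccccc3)c2cc1OC`: "not active" (no number reported)
- compound 2 `CN1CCN(c2cc3c(cc2F)c(=O)c(NC(=O)NCc2ccc(Cl)cc2)cn3Cc2ccc(Cl)cc2)CC1`: "not active" (no number reported)
- compound 3 `O=C(OCc1ccc(Cl)cc1)c1cn(Cc2ccc(Cl)cc2)c2cc(N3CCNCC3)c(F)cc2c1=O`: 1100 nM

Three compounds were tested in an ADME assay on Huh-7 cells (Homo sapiens) for cytotoxicity; on this read-out lower numbers stand for stronger inhibition of growth and higher numbers for weaker inhibition of growth. Compound 1 `COc1cc2c(=O)c(C(=O)c3ccc(C)cc3)cn(CCCc3ccccc3)c2cc1OC` gave no single number in this assay and is recorded as "not active" (no number reported). Compound 2 `CN1CCN(c2cc3c(cc2F)c(=O)c(NC(=O)NCc2ccc(Cl)cc2)cn3Cc2ccc(Cl)cc2)CC1` likewise is recorded as "not active" (no number reported). Only compound 3 `O=C(OCc1ccc(Cl)cc1)c1cn(Cc2ccc(Cl)cc2)c2cc(N3CCNCC3)c(F)cc2c1=O` gives a number in this assay, namely 1100 nM. No two of these compounds differ in a single place, so no step between measured compounds can be drawn, and compound 1 stands without a number among them.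

Compound 4 `COc1cc2c(=O)c(C(=O)c3ccc(C)cc3)cn(Cc3ccc(C(C)(C)C)cc3)c2cc1OC` is the untested analog of compound 1. The change is 4-(tert-butyl)phenyl in place of phenethyl on a saturated chain carbon bound to an aromatic nitrogen. The shared core of compound 1 and compound 4 is kept whole; only the group on the saturated chain carbon bound to the aromatic nitrogen is exchanged. Since compound 1 gave no number in this assay, the size of the step to compound 4 cannot be read from any measured pair; the expectation is that it stays close to compound 1, with no change beyond the scatter. Compound 4 is therefore expected to show weak inhibition of growth, estimated at 30000 nM with a range from 5000 nM to 100000 nM.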

Compound 4, concentration for 50% growth inhibition: > 25000 nM
Compound 4: no number, only a limit; the forecaster's own chance of this, stated with the estimate: 70%; the middle value is on the limit's open side.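

In this assay compound 4 gives > 25000 nM, which is a limit and not a number. For the compounds shown here, compound 1 has no number either, so no step between compound 1 and compound 4 can be read. The compounds shown leave open whether exchanging 3-phenylpropyl for 4-(tert-butyl)benzyl changes growth inhibition at all.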